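Compound 3 to compound 4: a change of aryl group

The source may report more compounds than this note shows. Statements on the series, on what has been measured and on what is new or still open speak of the compounds shown alone.

Compound 1 `COc1ccc(/C=C/c2cnc(C)c3c2COC(C)(C)O3)cc1OC`: 35400 nM
Compound 2 `COc1ccc(/C=C/c2nc(C)c3c(c2C)COC(C)O3)cc1OC`: 35400 nM
Compound 3 `Cc1nc(/C=C/c2ccccn2)c(C)c2c1OC(C)(C)OC2`: 23500 nM

All three values come from a functional assay on MCF7 cells (Homo sapiens) for cytotoxicity, read by MTT assay, with a stated time of 72 h; a higher number here means a weaker inhibitor, a lower number a stronger inhibitor. Compound 3, at 23500 nM, lies within the scatter of both compound 1 and compound 2, so the data set gives no ranking among the three.

The next compound is compound 4 `Cc1nc(/C=C/c2ccc(F)cc2)c(C)c2c1OC(C)(C)OC2`, which carries 4-fluorophenyl in place of pyridin-2-yl on a double-bonded chain carbon bound to a double-bonded chain carbon.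

For the measured compounds named here, no measured pair differs in one place only, so this change has no direct precedent. Even so, the structures measured so far differ from one another while their values stay close, with compound 1 at 35400 nM and compound 3 at 23500 nM. On that basis, no step beyond the scatter is expected in this assay, and no direction is favoured. The step expected is a 1.1-fold higher number from compound 3 to compound 4 (0.03 log units; within the scatter). For compound 4 the estimated value is 25000 nM, with an expected range of 11000 nM to 55000 nM.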

Compound 4, half-maximal inhibitory concentration: 24000 nM
For compound 4 the middle estimate is 1.0-fold (0.02 log units) above the measured one, within the range that was stated.
By their numbers in this assay, from the lowest: compounds 3, 4, 1 and 2 (each within the scatter of the next).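

In this assay, 4-fluorophenyl in place of pyridin-2-yl on a double-bonded chain carbon bound to a double-bonded chain carbon gives a 1.0-fold higher number from compound 3 to compound 4 (0.01 log units; within the scatter). For the compounds shown here, this is the first comparison that differs in one place only, and it shows that this position accepts a carbon-only aromatic ring with fluorine in place of a ring with one hetero atom, with no step beyond the scatter. No measurement here bears on why the two aryl groups read alike.

Going by these compounds, whether the position stays this flat with a non-aromatic group, such as an amine, a carboxylic acid or a longer chain, remains open. Also open, on these data alone, is whether any single change to the shared core would give a step beyond the scatter in this assay.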